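From nitro to methylcarbamoyl in compound 3

The source may hold more compounds than are shown below. What is called first, only, known or untested is meant among the compounds shown, and "the series" means these compounds.

Measured so far in a physicochemical assay for lipophilicity, at pH 7.4 (on this read-out lower numbers stand for lower lipophilicity and higher numbers for higher lipophilicity), for two compounds
Compound 1 `Cc1cc(/C=C/C#N)cc(C)c1Oc1cc(Nc2ccc(C#N)cc2)c(N)cc1[N+](=O)[O-]` gives > 5
Compound 2 `Cc1cc(CCC#N)cc(C)c1Oc1cc(Nc2ccc(C#N)cc2)c(N)cc1C(N)=O` gives 2.65

Going by these compounds, the entry for compound 1 is a limit of the assay and not a number, so its true position on the scale stays open. In the same assay, compound 2 has an exact reading. Compound 3 `CNC(=O)c1cc(N)c(Nc2ccc(C#N)cc2)cc1Oc1c(C)cc(/C=C/C#N)cc1C` has not yet been measured. It keeps the core of compound 1 but has methylcarbamoyl in place of nitro on an aromatic carbon para to a (4-cyanophenyl)amino group. Among the compounds with values here, no measured pair isolates this change. Although it differs from compound 3 elsewhere too, compound 2 also bears an amide group, and its reading of 2.65 is the only numerical anchor available. A large downward step, well beyond the scatter, is therefore expected in this assay and is estimated as a number at least 1.60 log units lower from compound 1 to compound 3 (beyond the scatter) for this change. For compound 3 the expected value is 3.4 on the estimate made here, with an expected range of 2.7 to 4.1 before any measurement is in hand.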

Compound 3, partition coefficient: 4.12
Estimate against measurement, compound 3: 0.72 log units below; measured number above the stated range.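

With compound 3, the aromatic carbon para to a (4-cyanophenyl)amino group gets its first direct comparison in this assay, and the change from nitro to methylcarbamoyl on the core of compound 1 comes out as a number at least 0.88 log units lower from compound 1 to compound 3 (beyond the scatter). Compound 1 stands at > 5, which is a limit of the assay and not a number. The step therefore fixes only the smallest size the change can have, and its full size stays unknown because one end of it rests on that limit: the limit of > 5 in this assay, at which 1 of the 3 values shown sits.

The compounds shown cannot separate what the methyl group of the methylcarbamoyl contributes from what the carbamoyl contributes, as compound 2, the only other amide here, also differs from compound 3 elsewhere, so no step between those two can be read. Going by these compounds, how an ethylcarbamoyl, a carboxylic acid or an amine at this position would read in this assay stays open, as does whether the same exchange on a different core would give a step of similar size.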